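Swapping propyl for phenyl on the ring nitrogen

The source may report more compounds than this note shows. Statements on the series, on what has been measured and on what is new or still open speak of the compounds shown alone.

Going by the values given here, in a functional assay on cells (Platelet, Homo sapiens) for inhibition (on this read-out lower numbers stand for stronger inhibition and higher numbers for weaker inhibition), compound 3 `CCCn1nc(-c2ccc(C(=O)OCC)cc2)c2ccccc21` gives 490 nM, the highest of the three numbers measured so far. Compound 1 `CCOC(=O)c1ccc(-c2nn(Cc3ccc(F)cc3)c3ccccc23)cc1` gives 190 nM, and compound 2 `CCOC(=O)c1ccc(-c2nn(Cc3ccccc3OC)c3ccccc23)cc1` gives 470 nM. The steps towards compound 3 were a 2.6-fold higher number from compound 1 to compound 3 (0.41 log units; beyond the scatter) and a 1.0-fold higher number from compound 2 to compound 3 (0.02 log units; within the scatter). Compound 4 `CCOC(=O)c1ccc(-c2nn(-c3ccccc3)c3ccccc23)cc1` differs from compound 3 by phenyl in place of propyl on an aromatic nitrogen. Both earlier steps changed a group on a saturated chain carbon bound to the aromatic nitrogen, not on the nitrogen itself, so they bear only loosely here. Still, a modestly lower number is expected, since compound 1 with its aromatic ring gave a 2.6-fold higher number from compound 1 to compound 3 (0.41 log units; beyond the scatter) relative to compound 3. Compound 4 is therefore estimated at 300 nM, within 120 nM to 900 nM. That expectation amounts to a step of a 1.6-fold lower number from compound 3 to compound 4 (0.21 log units; within the scatter).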

Compound 4, half-maximal inhibitory concentration: 2640 nM
Compound 4: middle estimate off by 8.8-fold (0.94 log units), on the low side, outside the stated range (above it).
By their numbers in this assay, from the lowest: compound 1; then compounds 2 and 3 (each within the scatter of the next); then compound 4.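

Phenyl in place of propyl on the aromatic nitrogen gives a clear rise in this assay (a 5.4-fold higher number from compound 3 to compound 4 (0.73 log units; beyond the scatter)), and the same holds against the 2-methoxybenzyl group (a 5.6-fold higher number from compound 2 to compound 4 (0.75 log units; beyond the scatter)) and the 4-fluorobenzyl group (a 14-fold higher number from compound 1 to compound 4 (1.14 log units; beyond the scatter)). An aromatic ring in this group therefore does not by itself give a lower number. Compounds 1, 2 and 3, each with a saturated chain carbon on the nitrogen, all give lower numbers than compound 4.

Going by these compounds, whether a longer chain such as butyl, or a benzyl group carrying an amine, would keep those lower numbers stays open. Nothing measured here explains the rise in compound 4.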